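Cyclohexyl for methoxyphenyl on a fused lactam nitrogen

The source may hold more compounds than are shown below. What is called first, only, known or untested is meant among the compounds shown, and "the series" means these compounds.

Measured compounds:
compound 1 `COc1cccc(N2C(=O)COc3ccc(-c4cnc(Cl)c(NS(=O)(=O)c5ccc(F)cc5)c4)cc32)c1` — > 40000 nM
compound 2 `O=C1COc2ccc(-c3cnc(Cl)c(NS(=O)(=O)c4ccc(F)cc4)c3)cc2N1C1CCCCC1` — > 40000 nM
compound 3 `COc1cccc(N2C(=O)COc3ccc(-c4cnc5ccccc5c4)cc32)c1` — 8240 nM

Of the compounds shown here, three have been tested in a functional assay on HCT-116 cells (Homo sapiens) for antiproliferative activity, read by MTT assay, with a stated time of 72 h; on this read-out lower numbers stand for stronger inhibition and higher numbers for weaker inhibition. Compound 1 `COc1cccc(N2C(=O)COc3ccc(-c4cnc(Cl)c(NS(=O)(=O)c5ccc(F)cc5)c4)cc32)c1` gives > 40000 nM, a limit of the assay rather than a number. Compound 2 `O=C1COc2ccc(-c3cnc(Cl)c(NS(=O)(=O)c4ccc(F)cc4)c3)cc2N1C1CCCCC1` likewise gives > 40000 nM, again a limit. Between them stands one change, (cyclohexyl in place of 3-methoxyphenyl on an amide-type nitrogen in a ring), and its step that the two limits leave unreadable from compound 1 to compound 2 cannot be read because both values sit at the limit of > 40000 nM in this assay, at which 2 of the 3 values shown sit. Compound 3 `COc1cccc(N2C(=O)COc3ccc(-c4cnc5ccccc5c4)cc32)c1` carries a different core; how its core differs from that of compound 1 is not broken down here. In this assay, within the data shown here, compound 3 gives 8240 nM, the only number among the three.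

Compound 4 `O=C1COc2ccc(-c3cnc4ccccc4c3)cc2N1C1CCCCC1` is not yet measured. It differs from compound 3 by cyclohexyl in place of 3-methoxyphenyl on an amide-type nitrogen in a ring, the same change as that from compound 1 to compound 2, at a place described in the same words. Since the earlier step gives no readable size, the expectation for compound 4 rests on the value of compound 3 alone, 8240 nM. Compound 4 is expected to lie near that value, with a step of a 1.5-fold higher number from compound 3 to compound 4 (0.16 log units; within the scatter) and an estimate of 12000 nM in this assay, between 4000 nM and 40000 nM.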

Compound 4, half-maximal inhibitory concentration: > 40000 nM
Compound 4 ended at the assay's limit (the forecaster's own chance of this, stated with the estimate: 30%); middle value at least 3.3-fold (0.52 log units) away from the limit.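

In this assay, putting cyclohexyl in place of 3-methoxyphenyl on the amide-type nitrogen gives an at least 4.8-fold higher number from compound 3 to compound 4 (0.68 log units; beyond the scatter), a step beyond the usual scatter. Compound 4 gives > 40000 nM, a limit of the assay and not a number, so only the smallest possible size of this step is known. The step from compound 1 to compound 2 cannot be read, so the change has a readable size on the core of compound 3 alone, and nothing shows whether it acts alike on the core of compound 1, because both of those compounds rest at the same limit: the limit of > 40000 nM in this assay, at which 3 of the 4 values shown sit.

The compounds shown leave open whether the aromatic ring of the 3-methoxyphenyl group or its methoxy group is what counts on this core. A plain phenyl or a 3-hydroxyphenyl on the same nitrogen would help to separate the two, and an amine-bearing chain there would test a quite different kind of group.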